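A few compounds are considered here, and "the series" means these few. Any claim that something is new, unique, unknown or untested is made for them only; others in the source may bear on it.

For the measured compounds named here, compound 3 `CNC(=O)c1cc(C(=O)NC2CC2)cn(Cc2cccc3[nH]ccc23)c1=O` is the one member of this set with a plain number in a physicochemical assay for solubility; on this read-out lower numbers stand for lower solubility and higher numbers for higher solubility: compound 3 gives 78 ug/mL. Compound 1 `CNC(=O)c1ccc(=O)n(Cc2cc(Br)ccc2F)c1` reaches a limit of the assay, >= 143 ug/mL, in this assay. Compound 2 `CNC(=O)c1cc(C(=O)NC2CCOCC2)cn(Cc2ccccc2)c1=O` likewise sits at a limit, >= 174 ug/mL, in this assay. Compound 4 `CNC(=O)c1cc(C(=O)NC2CC2)cn(Cc2ccc(C)cc2)c1=O` has not been measured; it differs from compound 3 by 4-methylphenyl in place of 1H-indol-4-yl on a saturated chain carbon bound to an aromatic nitrogen. Going by the values given here, no step between two measured compounds is available, so the size of this change is open. The step expected in this assay is a modest rise, a 1.4-fold higher number from compound 3 to compound 4 (0.15 log units; within the scatter), since the other members of the set sit at the limit of >= 143 ug/mL in this assay, at which 1 of the 3 values shown sits, and (the limit of >= 174 ug/mL in this assay, at which 1 of the 3 values shown sits). Compound 4 is therefore expected to give 110 ug/mL in this assay, with a range from 45 ug/mL to 260 ug/mL.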

Compound 4, solubility: 24 ug/mL
Beside the measured number, compound 4's estimate is 4.6-fold (0.66 log units) above it; measured number outside the range, below it.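

In this assay, 4-methylphenyl in place of 1H-indol-4-yl on a saturated chain carbon bound to an aromatic nitrogen gives a 3.3-fold lower number from compound 3 to compound 4 (0.51 log units; beyond the scatter) and so shows that this read-out responds to a change at this position. For the compounds shown here, the change swaps a two-ring group carrying a hydrogen-bond donor for a one-ring group without one, and the single step cannot separate these differences. No measurement shown accounts for the step.

Going by these compounds, whether a phenyl ring bearing an amine or a carboxylic acid at this position would return the number towards that of compound 3 remains open. Also open, on these data alone, is whether the step carries over to the other amide of compound 2.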